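This account rests on a few compounds, and the source may have more. Where it says the series, first, only, none or still open, it means among the compounds named here.

Measured compounds in a functional assay on MCF7 cells (Homo sapiens) for antiproliferative activity, read by sulforhodamine B assay, with a stated time of 48 h; on this read-out lower numbers stand for stronger inhibition and higher numbers for weaker inhibition:
compound 1, `CCCCCCCc1ccc(NS(=O)(=O)c2ccc(N3CCNC3=O)cc2)cc1`: compound 1 gives > 1000 nM, a limit of the assay.
compound 2, `CC(C)(C)c1ccc(NS(=O)(=O)c2ccc(N3CCNC3=O)cc2)cc1`: compound 2 gives > 1000 nM, a limit of the assay.
compound 3, `O=C1NCCN1c1ccc(S(=O)(=O)Nc2ccc(F)c(F)c2)cc1`: compound 3 gives 620 nM.

Among the measured compounds shown here, compound 3 holds the only number in this set; the other two values are limits, as the limit of > 1000 nM in this assay, at which 2 of the 3 values shown sit, records. For the measured compounds named here, the single measured step, a step that the two limits leave unreadable from compound 1 to compound 2, runs between two limits and gives no readable size. Compound 4, `COc1cccc(NS(=O)(=O)c2ccc(N3CCNC3=O)cc2)c1`, differs from compound 3 by 3-methoxyphenyl in place of 3,4-difluorophenyl on a sulfonamide nitrogen. Going by the values given here, no measured step touches this exchange, so the data give no direction for it. The expected step is a 1.5-fold higher number from compound 3 to compound 4 (0.16 log units; within the scatter), kept within the scatter. The estimate for compound 4 in this assay is 900 nM, within 400 nM to 2500 nM.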

Compound 4, half-maximal inhibitory concentration: 120 nM
Estimate against measurement, compound 4: 7.5-fold (0.88 log units) above; the whole stated range lies above it.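

Among the compounds shown here, on the sulfonamide nitrogen, the aryl group is not a silent part of the series: in this assay the exchange of 3,4-difluorophenyl for 3-methoxyphenyl gives a 5.2-fold lower number from compound 3 to compound 4 (0.71 log units; beyond the scatter) and is the only readable step in the set. A change in this group alone, with the core held constant, therefore moves the read-out beyond the scatter. Nothing shown gives a reason for this step.

Still open, on these data alone, is whether the shift follows the methoxy group itself or the loss of both fluorines. A 3-ethoxyphenyl or 3-aminophenyl group on the same nitrogen would help separate the two.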